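Halogen swap at the assay limit

This account rests on a few compounds, and the source may have more. Where it says the series, first, only, none or still open, it means among the compounds named here.

Compound 2 `CNC(=O)c1cc(Oc2ccc(NC(=O)c3cc(-c4ccc(Br)cc4)ncn3)cc2)ccn1` gives > 100000 nM in a functional assay on MCF7 cells (Homo sapiens) for cytotoxicity, read by MTT assay, with a stated time of 72 h (a lower number here means a stronger inhibitor, a higher number a weaker inhibitor), which is a limit and not a number. Compound 3 `CNC(=O)c1cc(Oc2ccc(NC(=O)c3nccc(-c4ccc([N+](=O)[O-])cc4)n3)cc2)ccn1` gives > 100000 nM in this assay, also a limit. Compound 1 `CNC(=O)c1cc(Oc2ccc(NC(=O)c3cc(-c4ccc(Cl)cc4)ncn3)cc2F)ccn1`, which also carries the 4-chlorophenyl, gives > 100000 nM in this assay, again a limit. Among the compounds with values here, the series so far shows (the limit of > 100000 nM in this assay, at which 3 of the 3 values shown sit), so no measured step is available. Compound 4 `CNC(=O)c1cc(Oc2ccc(NC(=O)c3cc(-c4ccc(Cl)cc4)ncn3)cc2)ccn1` differs from compound 2 by a single change: chloro in place of bromo on an aromatic carbon. The expected step is a number no higher from compound 2 to compound 4 (the limit leaves the size open), with no change beyond the scatter in either direction. For compound 4 the estimated value is 100000 nM, with an expected range of 30000 nM to 200000 nM.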

Compound 4, half-maximal inhibitory concentration: > 100000 nM
Compound 4 gave a limit, no number (the forecaster's own chance of this, stated with the estimate: 70%); the middle value lies on the limit itself.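

Compound 4, like compound 1 and compound 2, gives a limit and not a number, so neither step into compound 4 can be read. In this assay the compounds shown leave open which change to the shared core, if any, would give a measurable value.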